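Amide aryl swap on the shared core, weakest point

The source may hold more compounds than are shown below. What is called first, only, known or untested is meant among the compounds shown, and "the series" means these compounds.

Of the compounds shown here, three on a shared core have been measured in a functional assay on K562 cells (Homo sapiens) for cytotoxicity, read by WST assay, with a stated time of 72 h; a lower number here means a stronger inhibitor, a higher number a weaker inhibitor. Compound 1 `COc1cc2c(Nc3nc4ccc(C(=O)Nc5c(C)cc(C)cc5C)cc4s3)ncnc2cc1OCCCN1CCC(C)CC1` gives 5900 nM; compound 2 `COc1cc2c(Nc3nc4ccc(C(=O)Nc5c(C)cc(C)cc5C)cc4s3)ncnc2cc1OCCCN1CCCCC1C` gives 3500 nM; compound 3 `CCN(CC)CCCOc1cc2ncnc(Nc3nc4ccc(C(=O)Nc5c(C)cccc5Cl)cc4s3)c2cc1OC` gives 9600 nM. Compound 3 stands at the highest number of the three: its gap to compound 1 lies within the scatter, while its gap to compound 2 lies beyond it. For the measured compounds named here, the one measured step, a 1.7-fold lower number from compound 1 to compound 2 (0.23 log units; within the scatter), concerns the amine at the end of the chain and lies within the scatter.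

Compound 4 `CCN(CC)CCCOc1cc2ncnc(Nc3nc4ccc(C(=O)Nc5c(C)cc(C)cc5C)cc4s3)c2cc1OC` differs from compound 3 only at the amide: 2,4,6-trimethylphenyl in place of 2-chloro-6-methylphenyl on an amide-type nitrogen. Going by the values given here, no measured pair differs at this position alone, so the step from compound 1 to compound 2 does not bear on it, and the data give no guide in either direction. The expected change from compound 3 to compound 4 is therefore none beyond the scatter, a 1.3-fold lower number from compound 3 to compound 4 (0.11 log units; within the scatter). Compound 4 is estimated at 7500 nM, with a range from 2500 nM to 22000 nM.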

Compound 4, half-maximal inhibitory concentration: 6800 nM
Compound 4: middle estimate off by 1.1-fold (0.04 log units), on the high side; measured number inside the range.
By their numbers in this assay, from the lowest: compounds 2, 1, 4 and 3 (each within the scatter of the next, the first and the last beyond it).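

For the compounds shown here, at the amide, compound 3 and compound 4 are the first pair to differ there alone, and the exchange of 2-chloro-6-methylphenyl for 2,4,6-trimethylphenyl gives a 1.4-fold lower number from compound 3 to compound 4 (0.15 log units; within the scatter) in this assay, so this assay does not separate the two aryl groups. Going by these compounds alone, compound 4 also provides the first comparison of amines at the chain end: diethylamino in place of 4-methylpiperidin-1-yl gives a 1.2-fold higher number from compound 1 to compound 4 (0.06 log units; within the scatter), and in place of 2-methylpiperidin-1-yl it gives a 1.9-fold higher number from compound 2 to compound 4 (0.29 log units; within the scatter), so neither exchange moves the number beyond the scatter. No measurement is at hand that explains any of these steps.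

Open, as far as these compounds go, is whether an unsubstituted phenyl on the amide nitrogen, or a larger change such as a pyridine ring, would shift the number beyond the scatter. Equally open, from the compounds shown here alone, is whether a morpholine or a piperazine at the chain end, or a shorter chain, would do so.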